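The source may hold more compounds than are shown below. What is called first, only, known or untested is meant among the compounds shown, and "the series" means these compounds.

Measured compounds in a functional assay on HUVEC cells (Homo sapiens), read by scintillation counting and thymidine incorporation, with a stated time of 24 h; on this read-out higher numbers stand for weaker inhibition and lower numbers for stronger inhibition:

Compound 1 `CCC(C)n1ncn(-c2ccc(N3CCN(c4ccc(OC[C@@H]5CO[C@@](CN(C)C)(c6ccc(Cl)cc6Cl)O5)cc4)CC3)cc2)c1=O` gives 1400 nM.
Compound 2 `CCC(C)n1ncn(-c2ccc(N3CCN(c4ccc(OC[C@@H]5CO[C@@](Cn6cnc(C)n6)(c6ccc(Cl)cc6Cl)O5)cc4)CC3)cc2)c1=O` gives 272 nM.
Compound 3 `CCC(C)n1ncn(-c2ccc(N3CCN(c4ccc(OC[C@@H]5CO[C@@](Cn6cnc(C(F)(F)F)n6)(c6ccc(Cl)cc6Cl)O5)cc4)CC3)cc2)c1=O` gives 270 nM.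

Compound 2 stands second highest of the three numbers, where its nearest neighbour is compound 3, and these two lie within the scatter of each other, while compound 1 gives the highest number and is the furthest away. Compound 4 `CCC(C)n1ncn(-c2ccc(N3CCN(c4ccc(OC[C@@H]5CO[C@@](Cn6cccn6)(c6ccc(Cl)cc6Cl)O5)cc4)CC3)cc2)c1=O` has not yet been measured. It differs from compound 2 in one place: 1H-pyrazol-1-yl in place of 3-methyl-1H-1,2,4-triazol-1-yl on a saturated chain carbon bound to a saturated ring carbon.

Two measured steps show that replacing the dimethylamino group with a triazolyl ring gives a clearly lower number: a 5.1-fold lower number from compound 1 to compound 2 (0.71 log units; beyond the scatter) and a 5.2-fold lower number from compound 1 to compound 3 (0.71 log units; beyond the scatter). The third step, a 1.0-fold lower number from compound 2 to compound 3 (0.00 log units; within the scatter), shows that swapping one substituent for another on that ring changes nothing beyond the scatter. Within the data shown here, no measured step removes a ring nitrogen or the methyl together, so the step to compound 4 is expected to stay small, most likely within the scatter, as a 1.2-fold higher number from compound 2 to compound 4 (0.07 log units; within the scatter).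

Compound 4 is therefore estimated at 320 nM, with a range from 150 nM to 700 nM.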

Compound 4, half-maximal inhibitory concentration: 307 nM
The estimate for compound 4 lay 1.0-fold (0.02 log units) above the measured number; the measured number falls inside the stated range.
By their numbers in this assay, from the lowest: compounds 3, 2 and 4 (each within the scatter of the next); then compound 1.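

In this assay, the ring on the saturated chain carbon bound to a saturated ring carbon can be 1H-pyrazol-1-yl as well as a substituted triazolyl: the steps are a 1.1-fold higher number from compound 2 to compound 4 (0.05 log units; within the scatter) and a 1.1-fold higher number from compound 3 to compound 4 (0.06 log units; within the scatter), so the third ring nitrogen and the methyl or trifluoromethyl group make no difference beyond the scatter here. The advantage over dimethylamino also survives with this smaller ring, at a 4.6-fold lower number from compound 1 to compound 4 (0.66 log units; beyond the scatter), so among these compounds the lower number needs neither that nitrogen nor a ring substituent. No measurement is available that explains these results.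

The compounds shown leave open whether an aromatic ring is needed on this carbon at all. A phenyl ring or a morpholin-4-yl group there would help to settle this.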